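This account rests on a few compounds, and the source may have more. Where it says the series, first, only, none or still open, it means among the compounds named here.

Working notes on the series.

Two members of the series have been measured in a functional assay on CHO cells for antagonist activity at 5-hydroxytryptamine receptor 6 (Homo sapiens), read by luminescence and cAMP accumulation; on this read-out higher numbers stand for weaker inhibition and lower numbers for stronger inhibition. Compound 1 `CCN1CCN(c2cn(S(=O)(=O)c3ccc(F)cc3)c3ccc(Cl)cc23)CC1` gives 3.5 nM in this assay. Compound 2 `CN1CCN(c2cn(S(=O)(=O)c3ccc(F)cc3)c3ccc(Br)cc23)CC1` gives 3 nM in this assay. The two numbers sit within the usual scatter of each other, so compound 2 stands level with compound 1 on the read-out, and no ordering between the two can be drawn from the data.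

Compound 3 `CN1CCN(c2cn(S(=O)(=O)c3cccc(Cl)c3)c3ccc(Br)cc23)CC1` is not yet measured. It differs from compound 2 in one place: 3-chlorophenyl in place of 4-fluorophenyl on a sulfonyl sulfur. For the measured compounds named here, no measured pair in the set isolates a change of this kind, so nothing in the data points to a gain or a loss from it.

The step of a 1.7-fold higher number from compound 2 to compound 3 (0.22 log units; within the scatter) is expected to fall within the scatter, with no clear direction. Compound 3 is expected to give about 5 nM in this assay, within a range from 1.5 nM to 20 nM.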

Compound 3, antagonist equilibrium constant: 0.6 nM
Compound 3: the middle estimate sits 8.3-fold (0.92 log units) above what was measured; the measured number lies below the stated range.
By their numbers in this assay, from the lowest: compound 3; then compounds 2 and 1 (each within the scatter of the next).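

In this assay, for the compounds shown here, 3-chlorophenyl in place of 4-fluorophenyl on a sulfonyl sulfur gives a 5.0-fold lower number from compound 2 to compound 3 (0.70 log units; beyond the scatter) and is the first single-place step, showing that this position responds to the aryl group it carries. The two groups match in heavy atom count, hydrogen-bond donors and acceptors, and net charge, so the shift arises without a change in any of those counts. The change alters both the halogen and its numbering on the phenyl, and nothing available explains the lower number.

On these data alone, whether 4-chlorophenyl or 3-fluorophenyl would separate those two changes stays open. Also open, as far as these compounds go, is how an unsubstituted phenyl, a 3-methoxyphenyl or a pyridyl group would read at this position.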